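The source may report more compounds than this note shows. Statements on the series, on what has been measured and on what is new or still open speak of the compounds shown alone.

Values measured in a functional assay on SEM cells (Homo sapiens) for inhibition, read by MTT assay, with a stated time of 72 h; on this read-out higher numbers stand for weaker inhibition and lower numbers for stronger inhibition

Compound 1 `C=C(Br)C(=O)Nc1cccc(/C=C/C(=O)Nc2cccc(F)c2)c1` gives 620 nM
Compound 2 `C=C(Br)C(=O)Nc1cccc(/C=C/C(=O)Nc2ccc(Cl)cc2)c1` gives 1190 nM

Among the compounds with values here, only two compounds have been measured so far. Within the data shown here, compound 2, at 1190 nM, lies within the scatter of its single neighbour, compound 1, at 620 nM. The next structure is compound 3 `C=C(Br)C(=O)Nc1cccc(/C=C/C(=O)NCc2ccc(C)cc2)c1`, which differs from compound 2 at one place: 4-methylbenzyl in place of 4-chlorophenyl on an amide-type nitrogen. In other words, 4-methylbenzyl stands in place of 4-chlorophenyl on an amide-type nitrogen.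

Among the measured compounds shown here, only one measured step bears on this change. It concerns the same nitrogen, and a 1.9-fold higher number from compound 1 to compound 2 (0.28 log units; within the scatter) stays within the scatter. For the measured compounds named here, that step exchanges one substituted phenyl for another, however, and no measured compound carries a benzyl group there, so it offers only weak guidance. With no direction shown by the data, no shift beyond the scatter is expected in this assay, although the uncertainty is wide. The expected change is a 1.2-fold lower number from compound 2 to compound 3 (0.08 log units; within the scatter), which is an estimate and not a measurement. For compound 3 the estimated value is 1000 nM, with an expected range from 300 nM to 3500 nM.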

Compound 3, half-maximal inhibitory concentration: 1300 nM
The estimate for compound 3 lay 1.3-fold (0.11 log units) below the measured number, and the stated range covers the measured number.
By their numbers in this assay, from the lowest: compounds 1, 2 and 3 (each within the scatter of the next, the first and the last beyond it).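

In this assay, within the data shown here, the first benzyl group on this amide-type nitrogen gives a 1.1-fold higher number from compound 2 to compound 3 (0.04 log units; within the scatter) and so cannot be told apart from 4-chlorophenyl at this position, with one six-membered aromatic ring of carbon only present on both sides of the change. Among these compounds, measured against 3-fluorophenyl, the same group gives a 2.1-fold higher number from compound 1 to compound 3 (0.32 log units; beyond the scatter) and this modest step is the first in the set to pass beyond the scatter, while compound 2 remains within the scatter of both compound 1 and compound 3. Nothing available explains why these groups compare as they do.

Because 4-methylbenzyl differs from 4-chlorophenyl in both the ring substituent and the added carbon link, the compounds shown leave open how each change counts alone, which an unsubstituted benzyl or a 4-methylphenyl group on the same nitrogen would address. They also leave open whether this position tolerates a group with no aromatic ring, such as cyclohexyl, or a longer chain such as phenethyl, and whether a basic amine or a carboxylic acid on the ring would shift the number in this assay.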